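Working notes: fluoro for chloro at two places in one series

The source may hold more compounds than are shown below. What is called first, only, known or untested is meant among the compounds shown, and "the series" means these compounds.

Measured in a functional assay on A549 cells (Homo sapiens) for antiproliferative activity, read by MTT assay, with a stated time of 48 h, in the presence of a further agent that is not named here; on this read-out lower numbers stand for stronger inhibition of growth and higher numbers for weaker inhibition of growth:
- Compound 1, `Cc1ccc(-c2nn(-c3ccccc3)cc2C(=O)NOCc2ccccc2F)cc1`: 260 nM
- Compound 2, `Cc1ccc(-c2nn(-c3ccccc3)cc2C(=O)NOCc2ccccc2Cl)cc1`: 380 nM
- Compound 3, `O=C(NOCc1ccccc1)c1cn(-c2ccccc2)nc1-c1ccc(Cl)cc1`: 13000 nM

Compound 1 and compound 2 differ in one place only: fluoro in place of chloro on an aromatic carbon. The step that goes with it, a 1.5-fold lower number from compound 2 to compound 1 (0.16 log units; within the scatter), so the two numbers cannot be told apart here. Compound 3 carries a different core; how its core differs from that of compound 2 is not broken down here. Its number in this assay is the highest of the three, and the gaps to compound 2 and to compound 1 are both beyond the scatter.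

Compound 4, `O=C(NOCc1ccccc1)c1cn(-c2ccccc2)nc1-c1ccc(F)cc1`, is not yet measured. It differs from compound 3 by fluoro in place of chloro on an aromatic carbon. This is the same kind of change as from compound 2 to compound 1, not the same: there the place is ortho to a large group, here it is para to a large group. Going by the values given here, the step expected in this assay is a 1.3-fold lower number from compound 3 to compound 4 (0.11 log units; within the scatter), beside the earlier one, because a 1.5-fold lower number from compound 2 to compound 1 (0.16 log units; within the scatter) and no other pair shows the change at this place. Compound 4 is therefore estimated at 10000 nM, with an expected range from 4000 nM to 25000 nM.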

Compound 4, concentration for 50% growth inhibition: 10400 nM
Compound 4: the middle estimate sits 1.0-fold (0.02 log units) below what was measured; the range from low to high includes it.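

In this assay, the new pair gives a 1.3-fold lower number from compound 3 to compound 4 (0.10 log units; within the scatter), and the same change on the two cores reads alike: the same change on two cores in this assay, a 1.5-fold lower number (0.16 log units; within the scatter) from compound 2 to compound 1 and a 1.3-fold lower number (0.10 log units; within the scatter) from compound 3 to compound 4, 1.2-fold (0.07 log units) apart, within the scatter of two such steps

On these two cores, then, fluoro and chloro cannot be told apart, and this holds for the pair where the change is para to a large group as well as for the pair where it sits elsewhere. Going by these compounds alone, this does not show that the change is neutral across the series: there are only two pairs, and they differ in core and in the place of the change, so the two influences cannot be separated, and nothing follows for any further core.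

The compounds shown leave open whether a group other than a halogen, such as methoxy, an amine, a nitrile or a carboxylic acid, would also leave the number unchanged at either place. Also open, as far as these compounds go, is whether the agreement between the two pairs would survive a longer chain in place of the benzyl group on the amide side.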